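Working notes: 4-chlorophenyl in place of 3-methoxyphenyl

The source may report more compounds than this note shows. Statements on the series, on what has been measured and on what is new or still open speak of the compounds shown alone.

Compound 1 `COc1ccccc1S(=O)(=O)Nc1ccc(-c2nc3ccccc3o2)cc1`: in an assay on cells for inhibition of HSP60/HSP10 (Homo sapiens), with a stated time of 60 min (on this read-out lower numbers stand for stronger inhibition and higher numbers for weaker inhibition), compound 1 gives the limit > 100000 nM.
Compound 2 `COc1cccc(S(=O)(=O)Nc2ccc(-c3nc4ccccc4o3)cc2)c1`: in this assay compound 2 gives 80000 nM.

Going by the values given here, compound 2 holds the only number in this assay; the other value shown is the limit of > 100000 nM in this assay, at which 1 of the 2 values shown sits. Among the compounds with values here, the single measured step, an at least 1.2-fold lower number from compound 1 to compound 2 (0.09 log units; that floor lies within the scatter), lies within the scatter. Compound 3 `O=S(=O)(Nc1ccc(-c2nc3ccccc3o2)cc1)c1ccc(Cl)cc1` differs from compound 2 by 4-chlorophenyl in place of 3-methoxyphenyl on a sulfonyl sulfur. Within the data shown here, no measured step exchanges a methoxy for a chlorine, so that one step is the only guide, and it points to no step beyond the scatter. Compound 3 is therefore expected to give 80000 nM (range 40000 nM to 160000 nM), an expected step of no change at the digits printed from compound 2 to compound 3 (within the scatter).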

Compound 3, half-maximal inhibitory concentration: 61000 nM
Compound 3: middle estimate off by 1.3-fold (0.12 log units), on the high side; low and high end bracket the measured number.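

In this assay, the hydrogen-bond acceptor counted on 3-methoxyphenyl can go from the group on the sulfonyl sulfur with no change beyond the scatter, with a 1.3-fold lower number from compound 2 to compound 3 (0.12 log units; within the scatter). The change to 4-chlorophenyl from 2-methoxyphenyl gives only a floor, with an at least 1.6-fold lower number from compound 1 to compound 3 (0.21 log units; that floor lies within the scatter). Compound 1 remains a limit: the limit of > 100000 nM in this assay, at which 1 of the 3 values shown sits.

Going by these compounds, whether any group at this position moves the number beyond the scatter stays open. A phenyl carrying an amine or a carboxylic acid on the sulfonyl sulfur would bear on that question.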